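Adding a Second Bromine to Compound 3

A few compounds are considered here, and "the series" means these few. Any claim that something is new, unique, unknown or untested is made for them only; others in the source may bear on it.

Compound 3 `O=C(C1=NC(c2c[nH]c3ccccc23)CN1)c1c[nH]c2cc(Br)ccc12` was examined in an ADME assay on XF498 cells (Homo sapiens) for cytotoxicity; on this read-out lower numbers stand for an effect already at smaller amounts and higher numbers for an effect only at larger amounts of compound. For compound 3 the outcome is only a limit, > 30 ug/mL, which is the limit of > 30 ug/mL in this assay, at which 1 of the 3 values shown sits. Compound 1 `O=C1NC[C@@H](c2c[nH]c3ccccc23)N[C@H]1c1c[nH]c2ccccc12` likewise gives only a limit in this assay, > 10 ug/mL, which is the limit of > 10 ug/mL in this assay, at which 1 of the 3 values shown sits. Compound 2 `O=C(C1=NC(c2c[nH]c3cc(Br)ccc23)CN1)c1c[nH]c2ccccc12` gives 7.22 ug/mL in this assay. Compound 3 therefore stands at a limit rather than at a number, and one further value shown is a limit as well. Compound 4 `O=C(C1=NC(c2c[nH]c3cc(Br)ccc23)CN1)c1c[nH]c2cc(Br)ccc12` differs from compound 3 by bromo in place of hydrogen on an aromatic carbon. With compound 3 at a limit, the step to compound 4 in this assay is expected to run toward an effect at a smaller amount, estimated as an at least 3.0-fold lower number from compound 3 to compound 4 (0.47 log units; beyond the scatter). Compound 4 is expected to give about 10 ug/mL, between 4 ug/mL and 30 ug/mL.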

Compound 4, concentration for half-maximal effect: 5.16 ug/mL
Beside the measured number, compound 4's estimate is 1.9-fold (0.29 log units) above it, within the range that was stated.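

In this assay, placing bromo on this aromatic carbon gave an at least 5.8-fold lower number from compound 3 to compound 4 (0.76 log units; beyond the scatter), whereas the same kind of change at the other brominated carbon of compound 4 gave only a 1.4-fold lower number from compound 2 to compound 4 (0.15 log units; within the scatter). The same exchange therefore counts for much or little depending on where it is made, and the bromo that compound 2 already carries accounts for most of the gap. The first step has no fixed size, as compound 3 stands at a limit: the limit of > 30 ug/mL in this assay, at which 1 of the 4 values shown sits.

The compounds shown leave open how far the first step really reaches. They also leave open whether chloro, an amine or a methoxy group at this carbon would behave as bromo does.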